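This account rests on a few compounds, and the source may have more. Where it says the series, first, only, none or still open, it means among the compounds named here.

Going by the values given here, compound 2, `O=C(CN1CCC(c2cccc[n+]2[O-])CC1)Nc1cccc(Cl)c1`, gives 76% in a functional assay on HEK293 cells for agonist activity at D(4) dopamine receptor (Homo sapiens), read by FLIPR (on this read-out lower numbers stand for smaller maximal responses and higher numbers for larger maximal responses), the higher of the two numbers measured so far; compound 1, `CC(C)Oc1cccc(NC(=O)CN2CCC(c3cccc[n+]3[O-])CC2)c1`, gives 48%. Among the compounds with values here, the one measured step, a number 28 percentage points higher from compound 1 to compound 2 (beyond the scatter), involves this same aromatic carbon, where the group was exchanged. Compound 3, `O=C(CN1CCC(c2cccc[n+]2[O-])CC1)Nc1cccc(OC(F)(F)F)c1`, differs from compound 2 by trifluoromethoxy in place of chloro on an aromatic carbon. Within the data shown here, no measured step covers a trifluoromethoxy group, so the direction is uncertain; the single step only shows that an exchange at this position can move the response beyond the scatter. Compound 3 is expected to give about 65%, within 45% to 85%. That estimate means a step of a number 11 percentage points lower from compound 2 to compound 3 (beyond the scatter).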

Compound 3, largest response reached (reported as efficacy), in percent of the reference or control that the assay uses: 51%
Compound 3: the middle estimate sits 14 percentage points above what was measured; low and high end bracket the measured number.
By their numbers in this assay, from the lowest: compounds 1 and 3 (each within the scatter of the next); then compound 2.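

In this assay the step of a number 25 percentage points lower from compound 2 to compound 3 (beyond the scatter) shows that, at this aromatic carbon, trifluoromethoxy does not preserve the larger response seen with chloro. The step of a number 3 percentage points higher from compound 1 to compound 3 (within the scatter) shows that trifluoromethyl in place of isopropyl on the oxygen leaves the response within the scatter, so both oxygen-linked groups differ from chloro in the same direction. No evidence at hand accounts for either step. The compounds shown leave open how bromo, a nitrile or an amine at this carbon would compare with chloro.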